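The compounds below may be only part of what the source reports. "The series", "measured", "known", "first", "only" and "open" are said of these compounds alone.

Among the measured compounds shown here, in a functional assay on A549 cells (Homo sapiens) for cytotoxicity, read by MTT assay (on this read-out lower numbers stand for stronger inhibition and higher numbers for weaker inhibition), compound 1 `CCOC(=O)C(C)Oc1cc(O)c2c(=O)c(O)c(-c3ccc(OC)cc3)oc2c1CC=C(C)C` gives 26500 nM, the only number among the three compounds tested so far. Compound 2 `COc1ccc(-c2oc3c(CC=C(C)C)c(OCCO)cc(O)c3c(=O)c2OCCO)cc1` gives only a limit, > 100000 nM. Compound 3 `CCOC(=O)C(Oc1cc(O)c2c(=O)c(OC(C(=O)OCC)C(=O)OCC)c(-c3ccc(OC)cc3)oc2c1CC=C(C)C)C(=O)OCC` likewise gives only a limit, > 100000 nM.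

Compound 4 `COc1ccc(-c2oc3c(CC=C(C)C)c(OCC(=O)O)cc(O)c3c(=O)c2O)cc1` awaits measurement. It departs from compound 1 in one place, where carboxymethyl stands in place of 1-(ethoxycarbonyl)ethyl on an oxygen on an aromatic ring: carboxymethyl in place of 1-(ethoxycarbonyl)ethyl on an oxygen on an aromatic ring. For the measured compounds named here, no measured pair isolates this change. Going by the values given here, compound 1, at 26500 nM, is the only compound with a number, so a modest step toward weaker inhibition, beyond the scatter, is expected in this assay. The expected change is a 2.1-fold higher number from compound 1 to compound 4 (0.32 log units; beyond the scatter). Compound 4 is estimated at 55000 nM, with an expected range of 20000 nM to 100000 nM.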

Compound 4, half-maximal inhibitory concentration: 16700 nM
Estimate against measurement, compound 4: 3.3-fold (0.52 log units) above; measured number outside the range, below it.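

On an oxygen on an aromatic ring, carboxymethyl in place of 1-(ethoxycarbonyl)ethyl gives a 1.6-fold lower number from compound 1 to compound 4 (0.20 log units; within the scatter) in this assay, so the two groups cannot be told apart here. This first pair with two numbers shows that this oxygen can carry either the ethyl ester side chain or the carboxylic acid with a number still obtained.

Among the compounds shown here, compound 2 and compound 3 carry only a limit of the assay, so they add no step: the limit of > 100000 nM in this assay, at which 2 of the 4 values shown sit. How an amine, an amide or a longer chain on this oxygen would read remains open.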